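The compounds below may be only part of what the source reports. "The series", "measured", "known", "first", "only" and "open" are said of these compounds alone.

Working notes on the chalcone series in a functional assay on SK-MEL-5 cells (Homo sapiens) for inhibition; a lower number here means a stronger inhibitor of growth, a higher number a weaker inhibitor of growth.

Among the compounds with values here, compound 2 `O=C(/C=C/c1cccc(O)c1)c1cccc(-n2cc(-c3ccc(Cl)cc3)[nH]c2=O)c1` gives 1530 nM and stands at the lower of the two numbers known so far in this assay. Within the data shown here, its nearest neighbour is compound 1 `O=C(/C=C/c1cccc(O)c1)c1cccc(-n2cc(-c3ccccc3)[nH]c2=O)c1`, which in this assay gives 3180 nM; the only measured step in the set, a 2.1-fold lower number from compound 1 to compound 2 (0.32 log units; beyond the scatter), is a modest one and concerns the aromatic carbon on the ring attached to the shared core, not the chain end.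

Compound 3 `COc1cc(/C=C/C(=O)c2cccc(-n3cc(-c4ccc(Cl)cc4)[nH]c3=O)c2)ccc1O` differs from compound 2 at the other end of the molecule: 4-hydroxy-3-methoxyphenyl in place of 3-hydroxyphenyl on a double-bonded chain carbon bound to a double-bonded chain carbon. Among the measured compounds shown here, no measured step in the set touches this position, so the step from compound 1 to compound 2 gives no direct guide to its size or direction; it only shows that single changes have so far moved the number by a modest amount.

With nothing else to go on, compound 3 is expected to stay close to compound 2, the step of a 1.0-fold lower number from compound 2 to compound 3 (0.01 log units; within the scatter) being estimated as small and within the scatter, so that compound 3 is expected to give about 1500 nM in this assay, plausibly between 500 nM and 5000 nM.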

Compound 3, concentration for 50% growth inhibition: 1800 nM
Estimate against measurement, compound 3: 1.2-fold (0.08 log units) below; the range from low to high includes it.
By their numbers in this assay, from the lowest: compounds 2, 3 and 1 (each within the scatter of the next, the first and the last beyond it).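

In this assay, the step at the chain end, 4-hydroxy-3-methoxyphenyl in place of 3-hydroxyphenyl on a double-bonded chain carbon bound to a double-bonded chain carbon, comes to a 1.2-fold higher number from compound 2 to compound 3 (0.07 log units; within the scatter), so compound 2 and compound 3 cannot be told apart in this assay. This position therefore accepts a group of 9 heavy atoms in place of one of 7, with 2 hydrogen-bond acceptors in place of 1, and the number stays within the scatter, whereas the chloro step at the other end of the molecule was the only one so far to lie beyond it. No supporting measurement bears on why this change leaves the number where it is.

The reading rests on a single pair carrying the chloro group, and the compounds shown do not tell whether the same exchange would read the same way on the unsubstituted phenyl of compound 1, or what the hydroxy and methoxy groups each contribute alone. Also open, on these data alone, is whether an amine or a carboxylic acid on this ring, or a longer chain in place of the methoxy group, would stay within the scatter of compound 2.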